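A few compounds are considered here, and "the series" means these few. Any claim that something is new, unique, unknown or untested is made for them only; others in the source may bear on it.

Compound 1 `COC(=O)/C(=C/Cn1c(-c2ccccc2)ncc(NC(=O)OCc2ccccc2)c1=O)COC(=O)c1ccccc1`: 13.5 ug/mL in a functional assay on cells (Colon cell line, Homo sapiens) for inhibition; on this read-out higher numbers stand for weaker inhibition and lower numbers for stronger inhibition
Compound 2 `COC(=O)/C(=C/Cn1c(-c2ccccc2)ncc(NC(=O)OCc2ccccc2)c1=O)COC(C)=O`: > 50 ug/mL in this assay

Compound 2 gives only a limit of this assay, > 50 ug/mL, so its standing is known merely as a bound (the limit of > 50 ug/mL in this assay, at which 1 of the 2 values shown sits). Compound 3 `COC(=O)/C(=C/Cn1c(-c2ccccc2)ncc(NC(=O)OCc2ccccc2)c1=O)CO` differs from compound 2 by hydrogen in place of acetyl on an oxygen on a saturated carbon. Going by the values given here, the one measured step, an at least 3.7-fold higher number from compound 1 to compound 2 (0.56 log units; beyond the scatter), concerns a different change on the carbonyl carbon and offers no direct guide to removing the acetyl. With compound 2 already at the limit, compound 3 is expected to give 60 ug/mL, within 25 ug/mL to 150 ug/mL, and the step that the limit leaves unreadable from compound 2 to compound 3 is estimated as no step beyond the scatter.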

Compound 3, half-maximal inhibitory concentration: > 50 ug/mL
Compound 3 ended at the assay's limit; the forecaster's own chance of this, stated with the estimate: 70%; the middle value lies beyond the limit too.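

Compound 3 gives only a limit in this assay, > 50 ug/mL, and not a number. Hydrogen in place of benzoyl on this oxygen gives an at least 3.7-fold higher number from compound 1 to compound 3 (0.56 log units; beyond the scatter), so among the three compounds only the benzoyl ester has a readable value, and the free hydroxy group does not restore one. The step between the acetoxy and hydroxy compounds cannot be read, since both sit at the limit: the limit of > 50 ug/mL in this assay, at which 2 of the 3 values shown sit.

Still open, going by these compounds, is how far below that limit, if at all, either compound lies. Also open, on these data alone, is whether a larger acyl group such as naphthoyl, or an amine on this carbon, would give a readable value.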